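Indazole in Place of Pyridine: Expected Clearance of Compound 3

The source may hold more compounds than are shown below. What is called first, only, known or untested is meant among the compounds shown, and "the series" means these compounds.

Measured compounds:
compound 1 `CS(=O)(=O)c1ccc(-c2cc(C(O)(C(F)(F)F)C(F)(F)F)cnc2N2CCN(S(=O)(=O)c3ccc(N)nc3)CC2)cc1`: 103 mL.min-1.g-1
compound 2 `Nc1ccc(S(=O)(=O)N2CCN(c3ncc(C(O)(C(F)(F)F)C(F)(F)F)cc3-c3cccnc3)CC2)cn1`: 20 mL.min-1.g-1

In an ADME assay (liver) for metabolic stability, with Liver microsome (Rattus norvegicus) as the target, using microsomes and NADPH, with a stated time of 30 min, tested at 1 uM (a lower number here means slower removal, a higher number faster removal of the compound), compound 1 gives 103 mL.min-1.g-1 while compound 2 gives 20 mL.min-1.g-1. Among the compounds with values here, of these two numbers compound 2 stands lowest, the single measured step being a 5.2-fold lower number from compound 1 to compound 2 (0.71 log units; beyond the scatter), which arises when pyridin-3-yl replaces 4-(methylsulfonyl)phenyl on an aromatic carbon.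

Compound 3 `Nc1ccc(S(=O)(=O)N2CCN(c3ncc(C(O)(C(F)(F)F)C(F)(F)F)cc3-c3cccc4[nH]ncc34)CC2)cn1` differs from compound 2 in one place: 1H-indazol-4-yl in place of pyridin-3-yl on an aromatic carbon. Within the data shown here, no measured step covers this kind of exchange. Among the measured compounds shown here, the only step available, a 5.2-fold lower number from compound 1 to compound 2 (0.71 log units; beyond the scatter), concerns a different group at the same place, and shows merely that a change there can shift this assay beyond the scatter, in either direction as far as these data tell.

With so little to lean on, compound 3 is expected to lie somewhat above compound 2, a step of a 2.0-fold higher number from compound 2 to compound 3 (0.30 log units; within the scatter), though the range is wide. The estimate for compound 3 in this assay is 40 mL.min-1.g-1, between 12 mL.min-1.g-1 and 130 mL.min-1.g-1.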

Compound 3, intrinsic clearance in microsomes: 93 mL.min-1.g-1
For compound 3 the middle estimate is 2.3-fold (0.37 log units) below the measured one; measured number inside the range.
By their numbers in this assay, from the lowest: compound 2; then compounds 3 and 1 (each within the scatter of the next).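

In this assay, exchanging pyridin-3-yl for 1H-indazol-4-yl gives a 4.7-fold higher number from compound 2 to compound 3 (0.67 log units; beyond the scatter), so a change at this place on the aromatic carbon can raise the number as well as lower it. Set against 4-(methylsulfonyl)phenyl, 1H-indazol-4-yl gives a 1.1-fold lower number from compound 1 to compound 3 (0.04 log units; within the scatter), so these two different groups cannot be told apart here, and among the three groups only pyridin-3-yl stands apart. Nothing measured here explains why the groups differ in this way.

1H-indazol-4-yl differs from pyridin-3-yl both in its second ring and in its hydrogen-bond donor, and these compounds cannot separate the two. On these data alone, it also remains open whether a plain phenyl ring, or a pyridin-3-yl carrying an amine, would sit near compound 2 or near compound 3.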